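Bromo for nitro on a biaryl amide core

The compounds below may be only part of what the source reports. "The series", "measured", "known", "first", "only" and "open" are said of these compounds alone.

In a functional assay on the whole organism (lung) for inhibition, with Cavia porcellus as the target (on this read-out lower numbers stand for an effect already at smaller amounts and higher numbers for an effect only at larger amounts of compound), the measured compounds gave:
compound 1 `COc1ccc(-c2ccc(C(=O)N[C@H](C)CCCc3cccnc3)cc2Br)cc1OC`: 14 mg/kg
compound 2 `COc1ccc(-c2ccc(C(=O)N[C@H](C)CCCc3cccnc3)cc2[N+](=O)[O-])cc1OC`: 22 mg/kg
compound 3 `COc1ccc(-c2ccc(C(=O)NCCCCc3cccnc3)cc2[N+](=O)[O-])cc1OC`: 39 mg/kg

Compound 1 and compound 2 differ by one change, (bromo in place of nitro on an aromatic carbon), and the step was a 1.6-fold lower number from compound 2 to compound 1 (0.20 log units; within the scatter). Compound 3 differs from compound 2 by hydrogen in place of methyl on a saturated chain carbon bound to an amide-type nitrogen and a saturated chain carbon, with the step of a 1.8-fold higher number from compound 2 to compound 3 (0.25 log units; within the scatter). Going by the values given here, compound 4 `COc1ccc(-c2ccc(C(=O)NCCCCc3cccnc3)cc2Br)cc1OC` is not yet measured; it arises from compound 3 by bromo in place of nitro on an aromatic carbon, the same change as the one from compound 2 to compound 1. Beside that earlier step, the expected step is a 1.6-fold lower number from compound 3 to compound 4 (0.21 log units; within the scatter), resting on the earlier step because a 1.6-fold lower number from compound 2 to compound 1 (0.20 log units; within the scatter) and on compound 3 because 39 mg/kg. Compound 4 is therefore expected at 24 mg/kg, within 12 mg/kg to 48 mg/kg.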

Compound 4, dose for 50% inhibition: 19 mg/kg
Beside the measured number, compound 4's estimate is 1.3-fold (0.10 log units) above it; the measured number falls inside the stated range.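

Replacing nitro with bromo on the core without the chain methyl gave a 2.1-fold lower number from compound 3 to compound 4 (0.31 log units; beyond the scatter) in this assay, and this step agrees with the one seen on the methyl-bearing core: the same change on two cores in this assay, a 1.6-fold lower number (0.20 log units; within the scatter) from compound 2 to compound 1 and a 2.1-fold lower number (0.31 log units; beyond the scatter) from compound 3 to compound 4, 1.3-fold (0.12 log units) apart, within the scatter of two such steps.
Removing the chain methyl gave a 1.4-fold higher number from compound 1 to compound 4 (0.13 log units; within the scatter), which likewise agrees with the same change made on the nitro compounds: the same change on two cores in this assay, a 1.8-fold higher number (0.25 log units; within the scatter) from compound 2 to compound 3 and a 1.4-fold higher number (0.13 log units; within the scatter) from compound 1 to compound 4, 1.3-fold (0.12 log units) apart, within the scatter of two such steps.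
The two changes therefore carried over between these closely related cores, but two pairs in a single assay cannot show that either would carry over to a more different core, nor why the numbers moved as they did.

From the compounds shown here alone, it remains open whether another group in place of the bromo, such as chloro or nitrile, would give a similar step. A longer chain on the amide nitrogen is also untested among the compounds shown.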